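Removing the Ring Amide Substituent from Compound 3

The source may hold more compounds than are shown below. What is called first, only, known or untested is meant among the compounds shown, and "the series" means these compounds.

Compound 1 `COc1ccnc(NC[C@@H]2C[C@@H](OCC(=O)NC[C@H](NC(=O)C3(C)CCCCC3)C(=O)O)CN2C(=O)CC(C)(C)C)c1` gives 0.55 nM in an assay on a protein complex for inhibition of integrin alpha-5/beta-1 (Homo sapiens), read by ELISA; a higher number here means a weaker inhibitor, a lower number a stronger inhibitor.
Compound 2 `Cc1cc(C)c(S(=O)(=O)N[C@@H](CNC(=O)CO[C@@H]2C[C@@H](CNc3ccccn3)N(CCCc3ccccc3)C2)C(=O)O)c(C)c1` gives 670 nM in this assay.
Compound 3 `Cc1cc(C)c(S(=O)(=O)N[C@@H](CNC(=O)CO[C@@H]2C[C@@H](CNc3ccccn3)N(C(=O)CCc3ccccc3)C2)C(=O)O)c(C)c1` gives 25 nM in this assay.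

Compound 3 holds the second highest of the three numbers. Its nearest neighbour is compound 2, and the difference between them is a single change: a 27-fold lower number from compound 2 to compound 3 (1.43 log units; beyond the scatter). Compound 1, with a different acyl group on the same ring nitrogen and a different acid side chain, lies well below compound 3.

Compound 4 `Cc1cc(C)c(S(=O)(=O)N[C@@H](CNC(=O)CO[C@H]2CN[C@H](CNc3ccccn3)C2)C(=O)O)c(C)c1` takes the change one step further: hydrogen in place of phenethylcarbonyl on an amine nitrogen in a ring. Among the measured compounds shown here, no measured pair shows a free ring nitrogen, so the only guide is indirect. For the measured compounds named here, the one step on this nitrogen, a 27-fold lower number from compound 2 to compound 3 (1.43 log units; beyond the scatter), shows that an acyl group here is worth a great deal against an alkyl group, and both measured compounds with low numbers carry such an acyl group. Compound 4 is therefore expected to lose that advantage, and a 16-fold higher number from compound 3 to compound 4 (1.20 log units; beyond the scatter) is the estimated step. Compound 4 is expected to give about 400 nM, with a range from 60 nM to 4000 nM.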

Compound 4, half-maximal inhibitory concentration: 286 nM
Beside the measured number, compound 4's estimate is 1.4-fold (0.15 log units) above it; low and high end bracket the measured number.
By their numbers in this assay, from the lowest: compound 1; then compound 3; then compound 4; then compound 2.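

With a free ring nitrogen as the reference point, the two substituents at this position in this assay turn out to act in opposite directions. Removing phenethylcarbonyl costs potency, with an 11-fold higher number from compound 3 to compound 4 (1.06 log units; beyond the scatter), whereas removing 3-phenylpropyl gains a little, with a 2.3-fold lower number from compound 2 to compound 4 (0.37 log units; beyond the scatter), so the order runs from acyl through hydrogen to alkyl and the alkyl chain is worse than no substituent at all. Nothing available explains why these groups differ.

The compounds shown leave open how much of the gain belongs to the carbonyl alone and how much to the phenyl ring it carries, which an acetyl group or a small alkyl group such as methyl on this nitrogen would separate. They also leave open whether a sulfonyl group or a urea could take the place of the amide here.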